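A few compounds are considered here, and "the series" means these few. Any claim that something is new, unique, unknown or untested is made for them only; others in the source may bear on it.

In a functional assay on MKN-74 cells (Homo sapiens) for antiproliferative activity, with a stated time of 24 h; a higher number here means a weaker inhibitor, a lower number a stronger inhibitor:
compound 1 `NC(=O)c1c(NC(=O)c2ccccc2C(F)(F)F)sc2c1CCN(C(=S)Nc1ccccc1Cl)C2` gives 21900 nM
compound 2 `NC(=O)c1c(NC(=O)c2ccccc2C(F)(F)F)sc2c1CCN(C(=S)Nc1ccccc1F)C2` gives 19600 nM

Compound 2 and compound 1 sit within the scatter of each other, as the step of a 1.1-fold lower number from compound 1 to compound 2 (0.05 log units; within the scatter) shows; only these two numbers exist for the series. Compound 3 `NC(=O)c1c(NC(=O)c2ccccc2C(F)(F)F)sc2c1CCN(C(=S)Nc1ccccc1Br)C2` differs from compound 2 by bromo in place of fluoro on an aromatic carbon. Among the measured compounds shown here, the one step that bears on it is the halogen exchange a 1.1-fold lower number from compound 1 to compound 2 (0.05 log units; within the scatter), which was within the scatter, so no step beyond the scatter is expected in this assay for the exchange of fluoro for bromo either. Compound 3 is therefore estimated at 21000 nM, with a range from 9000 nM to 50000 nM, which means an expected step of a 1.1-fold higher number from compound 2 to compound 3 (0.03 log units; within the scatter).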

Compound 3, half-maximal inhibitory concentration: 23900 nM
For compound 3 the middle estimate is 1.1-fold (0.06 log units) below the measured one; the measured number falls inside the stated range.
By their numbers in this assay, from the lowest: compounds 2, 1 and 3 (each within the scatter of the next).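

In this assay bromo joins fluoro and chloro on the aromatic carbon ortho to a large group, and a 1.2-fold higher number from compound 2 to compound 3 (0.09 log units; within the scatter) and a 1.1-fold higher number from compound 1 to compound 3 (0.04 log units; within the scatter) both stay within the scatter. Compound 1, compound 2 and compound 3 therefore form one level, with no separation among these three halogens at this place. No measurement on hand bears on this result. Open, going by these compounds, is whether a non-halogen group here, such as methoxy, an amine or a carboxylic acid, would move the number beyond the scatter, and how plain phenyl compares.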